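Series notes: aryl variation on the saturated ring carbon

The source may report more compounds than this note shows. Statements on the series, on what has been measured and on what is new or still open speak of the compounds shown alone.

Three members of the series have been measured in a functional assay on SK-MEL-28 cells (Homo sapiens) for antiproliferative activity, with a stated time of 48 h; a lower number here means that less compound is tolerated, a higher number that more compound is tolerated. Compound 1 `Cc1cc(O)c(C2=NN(c3ccc(S(N)(=O)=O)cc3)C(c3ccccc3O)C2)cc1Cl` gives 37800 nM, compound 2 `Cc1cc(O)c(C2=NN(c3ccc(S(N)(=O)=O)cc3)C(c3ccccc3Cl)C2)cc1Cl` gives 52900 nM, and compound 3 `Cc1cc(O)c(C2=NN(c3ccc(S(N)(=O)=O)cc3)C(/C=C/c3ccccc3)C2)cc1Cl` gives 52000 nM. Compound 3 thus stands second highest of the three numbers, but the spread is small: the step of a 1.0-fold lower number from compound 2 to compound 3 (0.01 log units; within the scatter) and the step of a 1.4-fold higher number from compound 1 to compound 3 (0.14 log units; within the scatter) are both within the scatter, as is the step of a 1.4-fold higher number from compound 1 to compound 2 (0.15 log units; within the scatter).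

The next member is compound 4 `COc1ccc(C2CC(c3cc(Cl)c(C)cc3O)=NN2c2ccc(S(N)(=O)=O)cc2)cc1OC`. Its difference from compound 3 is 3,4-dimethoxyphenyl in place of 2-phenylethenyl on a saturated ring carbon. The two measured steps that change the group on this same saturated ring carbon, from compound 1 to compound 3 and from compound 2 to compound 3, were both within the scatter, so exchanging one aromatic group for another at this position has so far left the read-out in this assay unchanged. Among the measured compounds shown here, the incoming 3,4-dimethoxyphenyl group has no measured precedent here, so the expectation rests on those two steps alone.

For compound 4 the expected step is a 1.0-fold lower number from compound 3 to compound 4 (0.02 log units; within the scatter), that is, no change beyond the scatter. Compound 4 is therefore estimated at 50000 nM, with a range from 22000 nM to 110000 nM.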

Compound 4, concentration lethal to 50% of the cells: 62700 nM
Estimate against measurement, compound 4: 1.3-fold (0.10 log units) below; measured number inside the range.
By their numbers in this assay, from the lowest: compounds 1, 3, 2 and 4 (each within the scatter of the next).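

The saturated ring carbon now also accepts 3,4-dimethoxyphenyl, which enters with more heavy atoms than 2-phenylethenyl and with hydrogen-bond acceptors that 2-phenylethenyl lacks, yet this assay shows no change beyond the scatter for any of the three new exchanges: the step to the new compound from 2-phenylethenyl (a 1.2-fold higher number from compound 3 to compound 4 (0.08 log units; within the scatter)), the step from 2-chlorophenyl (a 1.2-fold higher number from compound 2 to compound 4 (0.07 log units; within the scatter)) and the step from 2-hydroxyphenyl (a 1.7-fold higher number from compound 1 to compound 4 (0.22 log units; within the scatter)). The last of these is the largest step seen so far at this position and still lies within the scatter, so all four groups on this carbon give numbers that cannot be told apart in this read-out. Nothing available on these compounds bears on this result.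

Still open, on these data alone, is whether a group without an aromatic ring at this carbon, such as a short alkyl chain, a carboxylic acid or an amine, would move the number beyond the scatter. Also open, as far as these compounds go, is whether replacing the 4-sulfamoylphenyl group or the 5-chloro-2-hydroxy-4-methylphenyl group on the shared core would do so in this assay.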